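This account rests on a few compounds, and the source may have more. Where it says the series, first, only, none or still open, it means among the compounds named here.

In an ADME assay on A549 cells (Homo sapiens) for cytotoxicity, read by resazurin assay, with a stated time of 48 h (a lower number here means that less compound is tolerated, a higher number that more compound is tolerated), three compounds sharing one core have been measured. Compound 1 `CN(C)c1ccc(NC(=O)c2cc(Cl)ccc2O)c(Cl)c1` gives 85100 nM, compound 2 `O=C(Nc1ccc(NCc2ccccc2)cc1Cl)c1cc(Cl)ccc1O` gives 19700 nM and compound 3 `O=C(Nc1ccc(NCc2cccc(C(F)(F)F)c2)cc1Cl)c1cc(Cl)ccc1O` gives 13300 nM as its half-maximal cytotoxic concentration. Compound 3 cannot be told apart from compound 2 on these numbers, and both lie under compound 1.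

Compound 4 `O=C(Nc1ccc(NCc2cccnc2Cl)cc1Cl)c1cc(Cl)ccc1O` has not yet been measured. It carries 2-chloropyridin-3-yl in place of 3-(trifluoromethyl)phenyl on a saturated chain carbon bound to a nitrogen on an aromatic ring.

Going by the values given here, two measured steps bear on this change. Benzylamino in place of dimethylamino on an aromatic carbon gave a 4.3-fold lower number from compound 1 to compound 2 (0.64 log units; beyond the scatter), so replacing a whole group at this nitrogen has moved the number. Trifluoromethyl in place of hydrogen on an aromatic carbon gave only a 1.5-fold lower number from compound 2 to compound 3 (0.17 log units; within the scatter), which suggests that changing the benzyl group matters little. No step beyond the scatter is therefore expected, and the estimate is a 1.4-fold higher number from compound 3 to compound 4 (0.13 log units; within the scatter) in this assay as a small drift at most. For compound 4 the expected value is 18000 nM, with an estimated range from 8000 nM to 40000 nM as the likely span.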

Compound 4, half-maximal cytotoxic concentration: 101000 nM
The estimate for compound 4 lay 5.6-fold (0.75 log units) below the measured number; the whole stated range lies below it.
By their numbers in this assay, from the lowest: compounds 3 and 2 (each within the scatter of the next); then compounds 1 and 4 (each within the scatter of the next).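

In this assay, the ring on the saturated chain carbon bound to a nitrogen on an aromatic ring clearly counts: 2-chloropyridin-3-yl in place of 3-(trifluoromethyl)phenyl gave a 7.6-fold higher number from compound 3 to compound 4 (0.88 log units; beyond the scatter), and 2-chloropyridin-3-yl in place of phenyl gave a 5.1-fold higher number from compound 2 to compound 4 (0.71 log units; beyond the scatter). The small trifluoromethyl step therefore did not speak for this position as a whole, and the earlier drop on moving away from dimethylamino does not hold for every replacement, since ((2-chloropyridin-3-yl)methyl)amino in place of dimethylamino gave a 1.2-fold higher number from compound 1 to compound 4 (0.07 log units; within the scatter). Nothing available explains this rise in the tolerated concentration.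

The new ring differs from phenyl in both its ring nitrogen and its chlorine, so these two changes cannot be separated here. A plain pyridine ring and a chlorophenyl ring at this position would be needed to tell how much each contributes.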